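Aryl amine variation on the shared core

This account rests on a few compounds, and the source may have more. Where it says the series, first, only, none or still open, it means among the compounds named here.

Compound 3 `C=C1[C@@H](OC(C)=O)C[C@@H]2[C@](C)(CO[Si](C)(C)C(C)(C)C)[C@H](OC(C)=O)CC[C@@]2(C)[C@@H]1C[C@@H](Nc1ccc(Br)cc1)C1=CCOC1=O` stands second highest of the three numbers in a functional assay on MCF7 cells (Homo sapiens) for cytotoxicity, read by sulforhodamine B assay (on this read-out lower numbers stand for stronger inhibition and higher numbers for weaker inhibition), giving 3920 nM. Compound 1 `C=C1[C@@H](OC(C)=O)C[C@@H]2[C@](C)(CO[Si](C)(C)C(C)(C)C)[C@H](OC(C)=O)CC[C@@]2(C)[C@@H]1C[C@@H](Nc1ccccc1)C1=CCOC1=O` gives 4840 nM in this assay, and compound 2 `C=C1[C@@H](OC(C)=O)C[C@@H]2[C@](C)(CO[Si](C)(C)C(C)(C)C)[C@H](OC(C)=O)CC[C@@]2(C)[C@@H]1C[C@@H](Nc1cccc(F)c1)C1=CCOC1=O` gives 3820 nM. All measured steps are small: a 1.3-fold lower number from compound 1 to compound 2 (0.10 log units; within the scatter), a 1.2-fold lower number from compound 1 to compound 3 (0.09 log units; within the scatter) and a 1.0-fold higher number from compound 2 to compound 3 (0.01 log units; within the scatter). Compound 4 `C=C1[C@@H](OC(C)=O)C[C@@H]2[C@](C)(CO[Si](C)(C)C(C)(C)C)[C@H](OC(C)=O)CC[C@@]2(C)[C@@H]1C[C@@H](Nc1cccc(OC)c1)C1=CCOC1=O` differs from compound 3 in one place: 3-methoxyphenyl in place of 4-bromophenyl on an amine nitrogen. Going by the values given here, no measured step brings in a methoxy group, so only the earlier ring exchanges bear on this one, and each of them lay within the scatter. The step to compound 4 in this assay is therefore expected to be a 1.0-fold higher number from compound 3 to compound 4 (0.01 log units; within the scatter), with no shift beyond the scatter. Compound 4 is estimated at 4000 nM, within a range of 2000 nM to 8000 nM.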

Compound 4, half-maximal inhibitory concentration: 28100 nM
Beside the measured number, compound 4's estimate is 7.0-fold (0.85 log units) below it, outside the stated range (above it).
By their numbers in this assay, from the lowest: compounds 2, 3 and 1 (each within the scatter of the next); then compound 4.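

In this assay the aryl group on the amine nitrogen turns out not to be indifferent: methoxy in place of hydrogen gives a 5.8-fold higher number from compound 1 to compound 4 (0.76 log units; beyond the scatter) and methoxy in place of fluoro gives a 7.4-fold higher number from compound 2 to compound 4 (0.87 log units; beyond the scatter) while the exchange of the whole aryl group gives a 7.2-fold higher number from compound 3 to compound 4 (0.86 log units; beyond the scatter) as well. Compound 2 and compound 3 stayed within the scatter of compound 1, so among these ring exchanges only the methoxy group of compound 4 moves the number, toward weaker inhibition. Nothing available accounts for this shift.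

Whether it belongs to methoxy alone remains open, since the compounds shown do not tell how a hydroxyl or an ethoxy group on the ring would read. A 4-methoxyphenyl group on the same nitrogen would show whether the ring position of the methoxy group matters.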